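Capping the hydroxy group of compound 3

The compounds below may be only part of what the source reports. "The series", "measured", "known", "first", "only" and "open" are said of these compounds alone.

In a functional assay on MDA-MB-231 cells (Homo sapiens) for cytotoxicity, read by MTT assay, with a stated time of 72 h (on this read-out higher numbers stand for an effect only at larger amounts of compound and lower numbers for an effect already at smaller amounts), compound 1 (`CCc1cccc2c(OC)c(-c3occ(C)c3C(=O)OC)ccc12`) gives 1.3 ug/mL. Compound 2 (`CCc1cccc2c(OC)c(-c3occ(C)c3C(=S)OC)ccc12`) gives 5.8 ug/mL, which is a 4.5-fold higher number from compound 1 to compound 2 (0.65 log units; beyond the scatter). Compound 3 (`CCc1cccc2c(OC)c(-c3occ(C)c3CO)ccc12`) is recorded only as a limit of the assay, > 10 ug/mL, and not as a number.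

Compound 4 (`CCc1cccc2c(OC)c(-c3occ(C)c3COCC(F)(F)F)ccc12`) differs from compound 3 in one place: 2,2,2-trifluoroethyl in place of hydrogen on an oxygen on a saturated carbon. Hydroxymethyl thus becomes (2,2,2-trifluoroethoxy)methyl.

Among the measured compounds shown here, two measured steps bear on this change, and both lead to the free hydroxy group of compound 3. The first is an at least 7.6-fold higher number from compound 1 to compound 3 (0.88 log units; beyond the scatter). The second is an at least 1.7-fold higher number from compound 2 to compound 3 (0.23 log units; that floor lies within the scatter), and its floor lies within the scatter. Compound 4 has no free hydroxy group, like compound 1 and compound 2, so some return toward their numbers is expected, though neither of them is an ether.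

The expected step is an at least 1.6-fold lower number from compound 3 to compound 4 (0.22 log units; that floor lies within the scatter), modest in size and toward a lower number. For compound 4 the estimate is 6 ug/mL, with an expected range from 2 ug/mL to 18 ug/mL.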

Compound 4, concentration for half-maximal effect: 5.3 ug/mL
Compound 4: middle estimate off by 1.1-fold (0.05 log units), on the high side; measured number inside the range.
By their numbers in this assay, from the lowest: compound 1; then compounds 4 and 2 (each within the scatter of the next). At a limit, above all of these: compound 3.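

Capping the hydroxy group with 2,2,2-trifluoroethyl gives a measured number where compound 3 had none, and the change reads as an at least 1.8-fold lower number from compound 3 to compound 4 (0.27 log units; that floor lies within the scatter). Compound 3 is recorded only as a limit of the assay, so this step has only a floor: the limit of > 10 ug/mL in this assay, at which 1 of the 4 values shown sits. The new ether side chain also shows that this position need not carry a carbonyl or thiocarbonyl group to give a measurable number, with a 1.1-fold lower number from compound 2 to compound 4 (0.04 log units; within the scatter), although the methoxycarbonyl of compound 1 still gives the lowest number, with a 4.1-fold higher number from compound 1 to compound 4 (0.61 log units; beyond the scatter).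

Going by these compounds, how large the gain from capping really is stays open, as does the share of the fluorine atoms in it. A plain ethyl ether would separate the capping from the fluorine atoms, and an amine on the same saturated carbon would test a different kind of group there.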